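A few compounds are considered here, and "the series" means these few. Any claim that something is new, unique, unknown or untested is made for them only; others in the source may bear on it.

Of the compounds shown here, three built on one shared core have been tested in a functional assay on REH cells (Homo sapiens) for cytotoxicity, read by MTT assay, with a stated time of 72 h; a lower number here means a stronger inhibitor, a higher number a weaker inhibitor. Compound 1 `O=C(CN1C(=O)/C(=C/c2ccc(-c3ccc(Cl)cc3)o2)SC1=S)NCc1ccc(C(F)(F)F)cc1` gives 170000 nM. Compound 2 `N#Cc1ccc(NC(=O)CN2C(=O)/C(=C/c3ccc(-c4ccc(Cl)cc4)o3)SC2=S)cc1` gives 90000 nM. Going by the values given here, compound 3 `O=C(CN1C(=O)/C(=C/c2ccc(-c3ccc(Cl)cc3)o2)SC1=S)NCc1ccc(Br)cc1` gives 75000 nM, the lowest of these three numbers; its nearest neighbour is compound 2, within the scatter, and the only step beyond the scatter is the modest one of a 2.3-fold lower number from compound 1 to compound 3 (0.36 log units; beyond the scatter).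

Compound 4 `O=C(CN1C(=O)/C(=C/c2ccc(-c3ccc(Cl)cc3)o2)SC1=S)NCc1ccccc1Cl` differs from compound 3 in one place: 2-chlorophenyl in place of 4-bromophenyl on a saturated chain carbon bound to an amide-type nitrogen. The measured steps that touch this same place are a 2.3-fold lower number from compound 1 to compound 3 (0.36 log units; beyond the scatter), a 1.2-fold lower number from compound 2 to compound 3 (0.08 log units; within the scatter) and a 1.9-fold lower number from compound 1 to compound 2 (0.28 log units; within the scatter); all are small, and two of them fall within the scatter. Changes at this place have so far moved this assay little, so for compound 4 a similarly small shift, in either direction or none beyond the scatter, is expected.

Compound 4 is estimated at 100000 nM, with a range from 40000 nM to 250000 nM. For compound 4 this estimate means a 1.3-fold higher number from compound 3 to compound 4 (0.12 log units; within the scatter), expected to stay within the scatter.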

Compound 4, half-maximal inhibitory concentration: 70000 nM
Compound 4: the middle estimate sits 1.4-fold (0.15 log units) above what was measured; low and high end bracket the measured number.
By their numbers in this assay, from the lowest: compounds 4, 3, 2 and 1 (each within the scatter of the next, the first and the last beyond it).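

In this assay, replacing 4-bromophenyl with 2-chlorophenyl alters both the halogen and its numbered place on the ring, yet the result is a 1.1-fold lower number from compound 3 to compound 4 (0.03 log units; within the scatter), so this double change leaves no measurable mark. The new compound also sits close to the nitrile-bearing compound, with a 1.3-fold lower number from compound 2 to compound 4 (0.11 log units; within the scatter), while a 2.4-fold lower number from compound 1 to compound 4 (0.39 log units; beyond the scatter) is the same modest kind of gap already seen with compound 3, leaving compound 1 apart from compounds 3 and 4 but not from compound 2. Nothing available explains why this place responds so little.

Every group shown here is a singly substituted phenyl or benzyl ring, so it remains open whether an amine or a carboxylic acid on that ring would shift the number further. A longer chain between the amide nitrogen and the ring is likewise untested in these compounds.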